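The compounds below may be only part of what the source reports. "The series", "measured", "known", "first", "only" and "open" are said of these compounds alone.

In an ADME assay on MDCK cells (Canis lupus familiaris) for cytotoxicity; a higher number here means that more compound is tolerated, a lower number that less compound is tolerated:
compound 1 `Cn1ccnc1Sc1cnc(C(C)(C)C)nc1-c1ccccc1O` gives 194000 ug/mL;
compound 2 `Cn1ccnc1Sc1cnc(-c2ccncc2)nc1-c1ccccc1O` gives 64700 ug/mL;
compound 3 `Cn1ccnc1Sc1cnc(-c2ccccc2)nc1-c1ccccc1O` gives 120000 ug/mL.

Compound 3 sits between the other two, and both gaps are within the scatter: a 1.6-fold lower number from compound 1 to compound 3 (0.21 log units; within the scatter) and a 1.9-fold higher number from compound 2 to compound 3 (0.27 log units; within the scatter). Compound 4 `Cn1ccnc1Sc1cnc(-c2ccc(N)cc2)nc1-c1ccccc1O` differs from compound 3 by amino in place of hydrogen on an aromatic carbon. For the measured compounds named here, no measured step alters this phenyl itself; the three steps all exchange the whole group at that place, and even the largest, a 3.0-fold lower number from compound 1 to compound 2 (0.48 log units; beyond the scatter), is only modest. Adding one small group while the ring stays touches less of the structure than any of these, so no step beyond the scatter is expected in this assay for compound 4. The estimate for compound 4 is 100000 ug/mL, within 50000 ug/mL to 200000 ug/mL, an expected step of a 1.2-fold lower number from compound 3 to compound 4 (0.08 log units; within the scatter) that stays within the scatter.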

Compound 4, half-maximal cytotoxic concentration: 80100 ug/mL
The estimate for compound 4 lay 1.2-fold (0.10 log units) above the measured number, and the stated range covers the measured number.
By their numbers in this assay, from the lowest: compounds 2, 4, 3 and 1 (each within the scatter of the next, the first and the last beyond it).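

In this assay, for the compounds shown here, amino in place of hydrogen, on an aromatic carbon para to a large group, is the first change to the phenyl itself, and it stays within the scatter (a 1.5-fold lower number from compound 3 to compound 4 (0.18 log units; within the scatter)). The 4-aminophenyl group also stays within the scatter against pyridin-4-yl (a 1.2-fold higher number from compound 2 to compound 4 (0.09 log units; within the scatter)), but against tert-butyl the step is modest and beyond it (a 2.4-fold lower number from compound 1 to compound 4 (0.38 log units; beyond the scatter)). No measurement here explains these steps.

On these data alone, whether a carboxylic acid or a longer chain on this phenyl would also stay within the scatter remains open.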